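Shortening the Amide Chain: From Compound 2 to Compound 4

The source may hold more compounds than are shown below. What is called first, only, known or untested is meant among the compounds shown, and "the series" means these compounds.

Three compounds have been measured in a functional assay on MGC-803 cells (Homo sapiens) for inhibition, read by MTT assay, with a stated time of 48 h; on this read-out lower numbers stand for stronger inhibition and higher numbers for weaker inhibition:
compound 1 `C/C=C/C(=O)N(Cc1ccc(OC)c([N+](=O)[O-])c1)c1cc(OC)c(OC)c(OC)c1` gives 590 nM
compound 2 `CCCCC(=O)N(Cc1ccc(OC)c(O)c1)c1cc(OC)c(OC)c(OC)c1` gives 66 nM
compound 3 `COc1cc(NCc2cccc(O)c2)cc(OC)c1OC` gives 57600 nM

Of these three numbers, compound 2 has the lowest, which on this read-out means the strongest inhibition. Its nearest neighbour is compound 1, whose number is higher by a margin beyond the usual scatter; compound 3 lies furthest away, with a number higher by a very large margin.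

Compound 4 `CCC(=O)N(Cc1ccc(OC)c(O)c1)c1cc(OC)c(OC)c(OC)c1` has not yet been measured. It differs from compound 2 in one place: hydrogen in place of ethyl on a saturated chain carbon, two bonds along the chain from a carbonyl carbon. Every other part of the two structures is the same. Among the compounds with values here, no pair among the measured compounds differs in only one place, so there is no measured step of this kind to lean on; the expectation rests on compound 2 alone. Since compound 2 gives 66 nM in this assay, the change from butylcarbonyl to propanoyl is expected to move the number only modestly, and if anything toward weaker inhibition, with an expected step of a 1.8-fold higher number from compound 2 to compound 4 (0.26 log units; within the scatter) that may well sit within the scatter. Compound 4 is therefore estimated at 120 nM in this assay, with a range from 40 nM to 400 nM.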

Compound 4, half-maximal inhibitory concentration: 50 nM
Beside the measured number, compound 4's estimate is 2.4-fold (0.38 log units) above it, within the range that was stated.
By their numbers in this assay, from the lowest: compounds 4 and 2 (each within the scatter of the next); then compound 1; then compound 3.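

Within the data shown here, this is the first pair that differs in only one place, and it shows that, in this assay, changing butylcarbonyl to propanoyl gives a 1.3-fold lower number from compound 2 to compound 4 (0.12 log units; within the scatter) and so cannot be told apart from repeat-measurement noise. At this saturated chain carbon, two bonds along the chain from a carbonyl carbon, the ethyl can therefore give way to hydrogen with no change this assay can resolve, and the low number of compound 2 does not depend on those two carbons. Nothing measured here explains this result.

Still open, as far as these compounds go, is what happens with a shorter acetyl group, a longer chain than butylcarbonyl, or a chain carrying an amine or a carboxylic acid. Compound 1 and compound 3 each differ from these two in more than one place, so they cannot answer this.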